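This account rests on a few compounds, and the source may have more. Where it says the series, first, only, none or still open, it means among the compounds named here.

Measured compounds:
compound 1, `C#CCNC1CCc2c(SCc3cccc(Br)c3)cccc21`: > 100000 nM
compound 2, `C#CCNC1CCc2c(SCc3cccc(C(F)(F)F)c3)cccc21`: 4.7 nM

The two measured compounds share one core and differ only in the group carried by the aromatic ring that hangs off the sulfur. In an assay on isolated protein for inhibition of Amine oxidase [flavin-containing] B (Homo sapiens) (on this read-out lower numbers stand for stronger inhibition and higher numbers for weaker inhibition), compound 1 gives > 100000 nM, which is a limit of the assay and not a number, so compound 1 stands at the weak end of what has been seen, sitting at the limit of > 100000 nM in this assay, at which 1 of the 2 values shown sits. In this assay compound 2 gives 4.7 nM. Among the compounds with values here, the one measured step, an at least 21000-fold lower number from compound 1 to compound 2 (4.32 log units; beyond the scatter), shows that changing the substituent on that aromatic ring can carry the read-out from the limit all the way to strong inhibition.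

Compound 3, `C#CCNC1CCc2c(SCc3ccc(C)cc3)cccc21`, is not yet measured. It differs from compound 1 by 4-methylphenyl in place of 3-bromophenyl on a saturated chain carbon bound to a sulfur. This change, like the measured step, removes the bromo group, but it brings in a methyl-bearing ring rather than a trifluoromethyl, so the measured step hints at the possible size of the effect without fixing its outcome. A downward step is expected, an at least 500-fold lower number from compound 1 to compound 3 (2.69 log units; beyond the scatter), with wide uncertainty. Compound 3 is estimated at 200 nM, within a range from 5 nM to 50000 nM.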

Compound 3, half-maximal inhibitory concentration: 1560 nM
Beside the measured number, compound 3's estimate is 7.8-fold (0.89 log units) below it; low and high end bracket the measured number.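

The step, an at least 64-fold lower number from compound 1 to compound 3 (1.80 log units; beyond the scatter), shows that a second group at this place, 4-methylphenyl, also brings the read-out well away from the limit, so trifluoromethyl is not the only replacement among those shown to do so. In this assay compound 3 gives 1560 nM and compound 2 gives 4.7 nM, so these printed values show that replacing 3-bromophenyl does not by itself lead to the low number of compound 2. The value of compound 1 is a limit of the assay and not a number, and it is now the only such value in the set: the limit of > 100000 nM in this assay, at which 1 of the 3 values shown sits.

The change from 3-bromophenyl to 4-methylphenyl alters both the group and the printed ring number, so the compounds shown cannot separate these two parts of the change, and 3-methylphenyl or 4-bromophenyl would be needed to tell them apart. Also open, from the compounds shown here alone, is what the read-out would be for a ring carrying an amine or a carboxylic acid, or for a longer chain in place of the saturated chain carbon bound to a sulfur.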